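Aryl exchange on the ring nitrogen: compound 3 ahead

This account rests on a few compounds, and the source may have more. Where it says the series, first, only, none or still open, it means among the compounds named here.

Two compounds of the shared core have numbers in a functional assay on A549 cells (Homo sapiens) for antiproliferative activity, read by MTT assay, with a stated time of 48 h; on this read-out lower numbers stand for stronger inhibition and higher numbers for weaker inhibition. Compound 1 `Cc1ccccc1-n1nncc1CN1C(=O)C2(C(C#N)=C(N)Oc3c(N)cc4nc5ccccc5nc4c32)c2ccccc21` gives 31700 nM. For the measured compounds named here, compound 2 `CCc1ccccc1-n1nncc1CN1C(=O)C2(C(C#N)=C(N)Oc3c(N)cc4nc5ccccc5nc4c32)c2ccccc21` gives 24600 nM, the lowest of the two numbers; the only step leading to it, a 1.3-fold lower number from compound 1 to compound 2 (0.11 log units; within the scatter), lies within the scatter, so compound 2 and compound 1 are not told apart on this read-out. Compound 3 `N#CC1=C(N)Oc2c(N)cc3nc4ccccc4nc3c2C12C(=O)N(Cc1cnnn1-c1ccc(F)cc1)c1ccccc12` is not yet measured. It differs from compound 2 in one place: 4-fluorophenyl in place of 2-ethylphenyl on an aromatic nitrogen. Going by the values given here, no measured step touches this place in a comparable way. The single step shown, a 1.3-fold lower number from compound 1 to compound 2 (0.11 log units; within the scatter), concerns only the methyl on the saturated chain carbon of the 2-ethylphenyl and stayed within the scatter, so it gives no direction for exchanging the whole aryl group. With nothing in the series pointing either way, the expected step is a 1.0-fold higher number from compound 2 to compound 3 (0.01 log units; within the scatter), that is, no change beyond the scatter, with a range wide enough to allow the aryl exchange to matter in either direction. Compound 3 is therefore estimated at 25000 nM, between 8000 nM and 80000 nM.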

Compound 3, half-maximal inhibitory concentration: > 50000 nM
Compound 3 gave a limit, no number; the forecaster's own chance of this, stated with the estimate: 15%; middle value at least 2.0-fold (0.30 log units) away from the limit.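

Compound 3 carries no number in this assay, only a limit: the limit of > 50000 nM in this assay, at which 1 of the 3 values shown sits.

For the compounds shown here, this is the first reading on the aryl group itself, on the aromatic nitrogen of the five-membered ring, whereas the earlier step touched only the chain on that aryl group. Exchanging the 2-ethylphenyl for 4-fluorophenyl gives an at least 2.0-fold higher number from compound 2 to compound 3 (0.30 log units; that floor lies within the scatter), and exchanging the 2-methylphenyl for 4-fluorophenyl gives an at least 1.5-fold higher number from compound 1 to compound 3 (0.19 log units; that floor lies within the scatter); each step is a floor that lies within the scatter, so compound 3 is not told apart from compound 2 or compound 1 on this read-out, and the exchange shows no lower number.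

On these data alone, the true size of either step remains open, as does whether any change would follow from losing the alkyl chain or from gaining the fluorine. A plain phenyl on the same aromatic nitrogen would separate those two parts of the exchange, and a pyridine ring in place of the aryl group, or an amine on it, would test the position more widely.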